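A few compounds are considered here, and "the series" means these few. Any claim that something is new, unique, unknown or untested is made for them only; others in the source may bear on it.

Going by the values given here, in an ADME assay for protein binding, using equilibrium dialysis, at pH 7.4, tested at 2 uM (on this read-out higher numbers stand for a larger free fraction and lower numbers for a smaller free fraction), compound 1 `CC1CC=C(C(=O)N(c2cc(C#CC(C)(C)C)sc2C(=O)O)C(C)C)CC1` gives 0.08, the higher of the two numbers so far, and compound 2 `CC(C)(C)C#Cc1cc(N(C(=O)[C@H]2CC[C@H](C)CC2)[C@H]2CC[C@H](Oc3cccnc3)CC2)c(C(=O)O)s1` gives 0.03, lower by more than the usual scatter. Compound 3 `CC(C)N(c1cc(C#CC(C)(C)C)sc1C(=O)O)C(=O)[C@H]1CC[C@H](C)CC1` has not been measured yet. It differs from compound 1 in one place, on a carbonyl carbon, with 4-methylcyclohexyl in place of 4-methylcyclohex-1-en-1-yl on a carbonyl carbon. Among the compounds with values here, no measured pair shows this change, so no step beyond the scatter is expected in this assay, and the estimated step is a 1.1-fold lower number from compound 1 to compound 3 (0.06 log units; within the scatter). For compound 3, the expected value is 0.07, with an estimated range of 0.04 to 0.12.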

Compound 3, unbound fraction: 0.06
Beside the measured number, compound 3's estimate is 1.2-fold (0.07 log units) above it; the range from low to high includes it.
By their numbers in this assay, from the lowest: compounds 2, 3 and 1 (each within the scatter of the next, the first and the last beyond it).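

On the carbonyl carbon, 4-methylcyclohexyl in place of 4-methylcyclohex-1-en-1-yl gives a 1.3-fold lower number from compound 1 to compound 3 (0.12 log units; within the scatter) in this assay, so losing this one double bond has no readable effect on the free fraction. Going by these compounds alone, this is the first pair differing in one place, which compound 1 and compound 2 alone could not provide. No measured evidence bears on this result. As far as these compounds go, both groups are rings of carbon only, so it remains open whether a piperidine ring, or a hydroxyl group on the cyclohexyl ring, would move the free fraction beyond the scatter.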